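This account rests on a few compounds, and the source may have more. Where it says the series, first, only, none or still open, it means among the compounds named here.

Measured compounds:
Compound 1, `CC(=O)OC[C@H]1O[C@@H](n2cc(CN3C(=O)/C(=C\c4ccccc4)c4ccccc43)nn2)[C@H](OC(C)=O)[C@@H](OC(C)=O)[C@@H]1OC(C)=O`, gives 24100 nM in a functional assay on DU-145 cells (Homo sapiens) for cytotoxicity, read by sulforhodamine B assay, with a stated time of 48 h; on this read-out higher numbers stand for weaker inhibition and lower numbers for stronger inhibition.
Compound 2, `CC(=O)OC[C@H]1O[C@@H](n2cc(CN3C(=O)/C(=C\c4cccs4)c4ccccc43)nn2)[C@H](OC(C)=O)[C@@H](OC(C)=O)[C@@H]1OC(C)=O`, gives 22800 nM in this assay.

Only these two numbers are known. Compound 2 and compound 1 lie within the scatter of each other, so neither can be called the more active of the two; on the numbers shown, compound 2 simply sits alongside compound 1. Within the data shown here, the one measured step, a 1.1-fold lower number from compound 1 to compound 2 (0.02 log units; within the scatter), swaps a phenyl for a thiophen-2-yl at the same place and leaves the read-out essentially unchanged.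

Compound 3, `CC(=O)OC[C@H]1O[C@@H](n2cc(CN3C(=O)/C(=C\c4ccco4)c4ccccc43)nn2)[C@H](OC(C)=O)[C@@H](OC(C)=O)[C@@H]1OC(C)=O`, is not yet measured. It differs from compound 2 in one place: furan-2-yl in place of thiophen-2-yl on a double-bonded chain carbon bound to a double-bonded ring carbon. This is again an exchange of one small aromatic ring for another at the same place, closely resembling the step from compound 1 to compound 2. Since that earlier exchange stayed within the scatter, no shift beyond the scatter is expected in this assay for compound 3, in either direction.

For compound 3 the expected step is therefore a 1.0-fold higher number from compound 2 to compound 3 (0.00 log units; within the scatter), and the estimated value is 23000 nM, with a range from 11000 nM to 48000 nM.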

Compound 3, half-maximal inhibitory concentration: 16900 nM
For compound 3 the middle estimate is 1.4-fold (0.13 log units) above the measured one; the measured number falls inside the stated range.
By their numbers in this assay, from the lowest: compounds 3, 2 and 1 (each within the scatter of the next).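

In this assay, the place on a double-bonded chain carbon bound to a double-bonded ring carbon has now held three different aromatic rings, and furan-2-yl takes its place alongside the other two: the data give a 1.3-fold lower number from compound 2 to compound 3 (0.13 log units; within the scatter) and a 1.4-fold lower number from compound 1 to compound 3 (0.15 log units; within the scatter). The first of these steps exchanges only the hetero atom of a five-membered aromatic ring, sulfur for oxygen, and the second exchanges a phenyl for that furan-2-yl, so neither kind of ring exchange separates these compounds on this read-out. No measurement is available that would explain this flat picture.

It remains open whether a group of a different kind at this place, such as an amine, a carboxylic acid or a longer chain, would give a number beyond the scatter, as all three compounds shown carry an aromatic ring there. Also open, as far as these compounds go, is whether a change elsewhere on the shared core, which is identical in all three compounds, would move the number in this assay further than any step seen so far.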